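The source may hold more compounds than are shown below. What is called first, only, known or untested is meant among the compounds shown, and "the series" means these compounds.

Of the compounds shown here, two from this series have been measured so far, and a third awaits its result. Compound 1 `CC(C)Cc1csc(N)c1C(=O)c1ccc(Cl)cc1` and compound 2 `CC(C)(C)Cc1c(-c2ccncc2)sc(N)c1C(=O)c1ccc(Cl)cc1` share a core carrying an amino group, and both were tested in an assay on CHO cells for displacement of a labelled ligand from adenosine receptor A3 (Homo sapiens), read by scintillation counting, tested at 10 uM; a lower number here means less inhibition, a higher number more inhibition at the concentration tested (going by the name of the read-out). In this assay compound 1 gives 1%, and compound 2 gives 6%. Among the compounds with values here, of the two numbers, the one for compound 2 is the larger, but the gap to compound 1 lies within the scatter, so no order between them can be claimed: both point to little inhibition at the concentration tested.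

Compound 3 `CC(C)(C)Cc1c(-c2ccc(Cl)cc2)sc(N)c1C(=O)c1ccc(Cl)cc1` differs from compound 2 in one place: 4-chlorophenyl in place of pyridin-4-yl on an aromatic carbon. Within the data shown here, no measured pair shows this exchange, so its effect cannot be read from the data at hand. Given that both measured values sit near the bottom of the scale, the step from compound 2 to compound 3 is expected to be small, a number 4 percentage points higher from compound 2 to compound 3 (within the scatter), with no direction claimed beyond the scatter. Compound 3 is therefore estimated at 10%, with a range from -5% to 30%.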

Compound 3, a percentage reported as inhibition, at one concentration (the size of the read-out at that concentration, not a potency): 1%
Beside the measured number, compound 3's estimate is 9 percentage points above it, within the range that was stated.
By their numbers in this assay, from the lowest: compounds 1, 3 and 2 (each within the scatter of the next).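

In this assay, within the data shown here, exchanging pyridin-4-yl for 4-chlorophenyl on the aromatic carbon next to the ring sulfur gives a number 5 percentage points lower from compound 2 to compound 3 (within the scatter), the first step that can be read at this position. With the neopentyl group and the rest of the molecule held constant, the departure of the ring nitrogen, with the hydrogen-bond acceptor counted for it, and the arrival of the chlorine leave the read-out within the scatter, and both compound 2 and compound 3 still show little inhibition. No evidence is available that bears on this result.

Among these compounds, the pair covers only two aromatic rings at this position, and with both values near the bottom of the scale it cannot show whether the position could support stronger inhibition. As far as these compounds go, whether an aliphatic amine or a carboxylic acid on this ring carbon, or a longer chain in place of the neopentyl group, would move the read-out beyond the scatter remains open.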